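A few compounds are considered here, and "the series" means these few. Any claim that something is new, unique, unknown or untested is made for them only; others in the source may bear on it.

Working notes on the series. The three measured compounds share one core and differ only in the group on the six-membered aromatic ring. In an assay on isolated protein for inhibition of alkaline phosphatase, tissue-nonspecific isozyme (Homo sapiens) (on this read-out higher numbers stand for weaker inhibition and lower numbers for stronger inhibition), compound 1 `COc1ccc(Cl)cc1S(=O)(=O)Nc1cncc(-c2cccnc2)c1` gives 73 nM. Compound 2 `COc1ccc(Cl)cc1S(=O)(=O)Nc1cncc(-c2cccc(C)c2)c1` gives 160 nM in this assay. Compound 3 `CNC(=O)c1cncc(NS(=O)(=O)c2cc(Cl)ccc2OC)c1` gives 109 nM in this assay, which is the second highest of the three numbers; compound 2 is nearest and compound 1 furthest, and both gaps lie within the scatter. Of the measured steps, a 2.2-fold higher number from compound 1 to compound 2 (0.34 log units; beyond the scatter) is beyond the scatter, whereas a 1.5-fold higher number from compound 1 to compound 3 (0.17 log units; within the scatter) and a 1.5-fold lower number from compound 2 to compound 3 (0.17 log units; within the scatter) are within it.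

Compound 4 `COc1ccc(Cl)cc1S(=O)(=O)Nc1cncc(-c2ccncc2)c1` differs from compound 3 in one place: pyridin-4-yl in place of methylcarbamoyl on an aromatic carbon. The step that bears on this most directly is the exchange of a pyridinyl ring against the methylcarbamoyl, seen in reverse in a 1.5-fold higher number from compound 1 to compound 3 (0.17 log units; within the scatter), which stayed within the scatter. Among the compounds with values here, no measured compound carries pyridin-4-yl, so the shift of the ring nitrogen has no precedent here. Compound 4 is therefore expected to land near compound 1, with a step of a 1.4-fold lower number from compound 3 to compound 4 (0.13 log units; within the scatter) expected, within the scatter. Compound 4 is estimated at 80 nM, with a range from 35 nM to 200 nM.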

Compound 4, half-maximal inhibitory concentration: 73 nM
Beside the measured number, compound 4's estimate is 1.1-fold (0.04 log units) above it, within the range that was stated.
By their numbers in this assay, from the lowest: compounds 1, 4, 3 and 2 (each within the scatter of the next, the first and the last beyond it).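

The exchange of pyridin-3-yl for pyridin-4-yl gives no change at the digits printed from compound 1 to compound 4 (within the scatter) in this assay, so the location of the ring nitrogen does not register at this position across these two pyridinyl groups. Compound 4 also repeats what compound 1 showed against the 3-methylphenyl group, with a 2.2-fold lower number from compound 2 to compound 4 (0.34 log units; beyond the scatter) as a second step beyond the scatter, so this difference does not rest on compound 1 alone. The methylcarbamoyl group, which has no ring, stays level with pyridin-4-yl, with a 1.5-fold lower number from compound 3 to compound 4 (0.17 log units; within the scatter) within the scatter, so an aromatic ring at this carbon is not required to remain in this range.

From the compounds shown here alone, whether a carboxylic acid, an amine, a longer alkyl chain or an unsubstituted phenyl group at this carbon would stay in this range remains open. Nothing at hand explains any of these steps.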